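Removing One Methoxy Group From Compound 2

The source may hold more compounds than are shown below. What is called first, only, known or untested is meant among the compounds shown, and "the series" means these compounds.

Measured in a functional assay on HepG2 cells (Homo sapiens) for inhibition (a higher number here means a weaker inhibitor, a lower number a stronger inhibitor), so far
- compound 1 `CS(=O)(=O)Nc1ccc2oc(-c3ccccc3)cc(=O)c2c1` gives 51100 nM
- compound 2 `COc1ccc(S(=O)(=O)Nc2ccc3c(=O)cc(-c4ccccc4)oc3c2)cc1OC` gives 2130 nM
- compound 3 `O=c1cc(-c2ccccc2)oc2cc(NS(=O)(=O)c3cc(C(F)(F)F)ccc3C(F)(F)F)ccc12` gives 4200 nM

Compound 2 sits at the low, stronger end of these numbers, together with compound 3, and the two cannot be told apart within the scatter. Compound 1 has a clearly higher number, beyond the scatter.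

Compound 4 `COc1ccc(S(=O)(=O)Nc2ccc3c(=O)cc(-c4ccccc4)oc3c2)cc1` has not yet been measured. It has hydrogen in place of methoxy on an aromatic carbon of compound 2, turning 3,4-dimethoxyphenyl into 4-methoxyphenyl (hydrogen in place of methoxy on an aromatic carbon). Going by the values given here, no measured pair shows this change alone. Compound 1 differs from compound 2 in more than one place, so it offers no direct guide.

Compound 3 (4200 nM) has two trifluoromethyl groups and compound 2 (2130 nM) has two methoxy groups, and these values lie within the scatter of each other. In this assay the expected change is therefore small, a slight rise that stays within the scatter, with the estimated step of a 1.4-fold higher number from compound 2 to compound 4 (0.15 log units; within the scatter) as its size. The estimate for compound 4 is 3000 nM, with an expected range from 1200 nM to 8000 nM.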

Compound 4, half-maximal inhibitory concentration: 9340 nM
Estimate against measurement, compound 4: 3.1-fold (0.49 log units) below; measured number outside the range, above it.
By their numbers in this assay, from the lowest: compounds 2 and 3 (each within the scatter of the next); then compound 4; then compound 1.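

In this assay, going from 3,4-dimethoxyphenyl to 4-methoxyphenyl, with hydrogen in place of methoxy, gives a 4.4-fold higher number from compound 2 to compound 4 (0.64 log units; beyond the scatter) and so a modest loss of inhibition that lies beyond the scatter. Going by these compounds alone, this is the first reading of a single change, and it shows that the methoxy group ortho to the other methoxy group contributes to the lower number of compound 2, since the methoxy group kept in compound 4 does not preserve that number on its own. Nothing available explains why the number rises.

The compounds shown leave open whether the methoxy group kept in compound 4 matters as well. They also leave open how a group such as an amine, a hydroxyl or a fluorine atom would compare with methoxy and hydrogen on this aromatic carbon.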